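The source may hold more compounds than are shown below. What is called first, only, known or untested is meant among the compounds shown, and "the series" means these compounds.

Measured in an ADME assay on Ava5 cells (Homo sapiens) for cytotoxicity; on this read-out lower numbers stand for higher toxicity in this test and higher numbers for lower toxicity in this test:
compound 1, `NC(=S)Nc1cccc(OCCCCCCCc2ccccc2)c1`, 23000 nM
compound 2, `NC(=S)Nc1cccc(OCCCCCOc2ccccc2)c1`, a limit of this assay, > 50000 nM
compound 3, `NC(=S)Nc1cccc(OCCCCCOc2ccc(Br)cc2)c1`, 19000 nM

Compound 3 and compound 1 sit within the scatter of each other in this assay, the step being a 1.2-fold lower number from compound 1 to compound 3 (0.08 log units; within the scatter). The third value, that of compound 2, is a limit and not a number. Compound 4, `NC(=S)Nc1cccc(OCCCCCOc2ccccn2)c1`, has not been measured in this assay. It differs from compound 3 in one place: pyridin-2-yl in place of 4-bromophenyl on an oxygen on a saturated carbon.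

Going by the values given here, two measured steps bear on this change. The step of an at least 2.6-fold lower number from compound 2 to compound 3 (0.42 log units; beyond the scatter) shows the bromine alone; compound 4 has no bromine, so that step read backwards points to a higher number. The step of an at least 2.1-fold higher number from compound 1 to compound 2 (0.33 log units; beyond the scatter) and the step of a 1.2-fold lower number from compound 1 to compound 3 (0.08 log units; within the scatter) show the same contrast against compound 1. Among the compounds with values here, no measured step covers the ring nitrogen that enters with the pyridin-2-yl group, so its contribution is unknown. Resting on the loss of the bromine alone, the expected step is a 2.4-fold higher number from compound 3 to compound 4 (0.37 log units; beyond the scatter). Compound 2 ended at the assay limit (the limit of > 50000 nM in this assay, at which 1 of the 3 values shown sits), and the same outcome is plausible here. Compound 4 is estimated at 45000 nM, within 20000 nM to 60000 nM.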

Compound 4, half-maximal cytotoxic concentration: > 50000 nM
Compound 4: no number, only a limit; the forecaster's own chance of this, stated with the estimate: 40%; at least 1.1-fold (0.04 log units) between middle value and limit.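

In this assay, pyridin-2-yl on this oxygen gives an at least 2.6-fold higher number from compound 3 to compound 4 (0.42 log units; beyond the scatter), and the (pyridin-2-yl)oxy group compared with the phenethyl end gives an at least 2.1-fold higher number from compound 1 to compound 4 (0.33 log units; beyond the scatter), so both readable steps from compound 4 run towards lower toxicity in the test. Compound 4 gives > 50000 nM, a limit and not a number, which shows that a ring nitrogen at this position does not bring back a measurable cytotoxic concentration of the kind seen with the 4-bromophenyl group. The step between compound 2 and compound 4 cannot be read, so the ring nitrogen cannot be told apart from the plain phenyl ring, and the result adds a second compound at the top of the measurable range: the limit of > 50000 nM in this assay, at which 2 of the 4 values shown sit.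

Still open, on these data alone, is whether the bromine itself or any substituent on this ring lowers the number, as a 4-chlorophenyl, a 4-methoxyphenyl or a bromo-substituted pyridine would show, and whether pyridin-3-yl or pyridin-4-yl behaves like pyridin-2-yl. Also open, as far as these compounds go, is how a shorter or longer chain between the two oxygens, or an amine on the terminal ring, would read against the same limit.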